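Widening one ring on compound 1

This account rests on a few compounds, and the source may have more. Where it says the series, first, only, none or still open, it means among the compounds named here.

Compound 1 `C[C@@H](O)[C@H]1C(=O)N2C(C(=O)OCOC(=O)O[C@H]3CCCc4ccccc43)=C(S[C@@H]3CN[C@H](C(=O)N(C)C)C3)[C@H](C)[C@H]12`: 0.0233 h
Compound 2 `CC(=O)N1C[C@@H](SC2=C(C(=O)OCOC(=O)O[C@H]3CCCCc4ccccc43)N3C(=O)[C@H]([C@@H](C)O)[C@H]3[C@H]2C)C[C@H]1C(=O)N(C)C`: 0.467 h

In a physicochemical assay for metabolic stability, read by HPLC, at pH 7.4, tested at 100 uM (a lower number here means that the compound disappears faster, a higher number that the compound lasts longer), compound 1 (0.0233 h) holds the lower of the two numbers, and compound 2 (0.467 h) lies beyond the scatter above it. Compound 3 `C[C@@H](O)[C@H]1C(=O)N2C(C(=O)OCOC(=O)O[C@@H]3CCCCc4ccccc43)=C(S[C@@H]3CN[C@H](C(=O)N(C)C)C3)[C@H](C)[C@H]12` is not yet measured. It departs from compound 1 at one place, on an oxygen next to a carbonyl group: a group of 11 heavy atoms (11 carbon; one six-membered aromatic ring of carbon only, one seven-membered non-aromatic ring of carbon only) in place of a group of 10 heavy atoms (10 carbon; one six-membered non-aromatic ring of carbon only, one six-membered aromatic ring of carbon only), on an oxygen next to a carbonyl group. In words, a six-membered non-aromatic ring of carbon only gives way to a seven-membered one, and the aromatic ring stays.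

Going by the values given here, no measured pair shows this change alone, so the data offer no direct precedent. Nothing beyond the scatter is expected in this assay, and the expectation starts from compound 1 (0.0233 h). The expected change is a 1.3-fold higher number from compound 1 to compound 3 (0.11 log units; within the scatter). The estimated half-life of compound 3 is 0.03 h, with an expected range from 0.012 h to 0.07 h.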

Compound 3, half-life: 0.45 h
For compound 3 the middle estimate is 15-fold (1.18 log units) below the measured one; measured number outside the range, above it.
By their numbers in this assay, from the lowest: compound 1; then compounds 3 and 2 (each within the scatter of the next).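

In this assay, the group on the oxygen next to a carbonyl group proves able to move the read-out on its own: replacing the six-membered non-aromatic ring with a seven-membered one, while the aromatic ring stays, gives a 19-fold higher number from compound 1 to compound 3 (1.29 log units; beyond the scatter) and lies beyond the scatter. Compound 1 and compound 2 differ in more than one place, so they could not isolate any single change at this position. Nothing measured here accounts for the size of this step.

Going by these compounds alone, only two ring sizes appear at this position, so it remains open how an eight-membered ring or an open benzyl group would compare. From the compounds shown here alone, it is also open whether an amine on the aromatic ring would leave the half-life of compound 3 unchanged.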